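The compounds below may be only part of what the source reports. "The series", "measured", "known", "first", "only" and "open" are said of these compounds alone.

In a functional assay on CWR22R cells (Homo sapiens) for antiproliferative activity, read by propidium iodide staining, with a stated time of 96 h (a lower number here means a stronger inhibitor, a higher number a weaker inhibitor), compound 3 `CC(O)(COc1cccc(C(F)(F)F)c1)C(=O)Nc1cccc(S(F)(F)(F)(F)F)c1` gives 28900 nM. Compound 2 `CC(O)(COc1cccc(S(F)(F)(F)(F)F)c1)C(=O)Nc1cccc(S(F)(F)(F)(F)F)c1`, at 27300 nM, sits level with it, while compound 1 `CC(O)(COc1ccc(S(F)(F)(F)(F)F)cc1)C(=O)Nc1cccc(S(F)(F)(F)(F)F)c1` gives a lower number, 10200 nM. Compound 3 therefore shares the high end of this small set with compound 2, and neither reaches compound 1.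

The next compound, compound 4 `CC(O)(COc1ccc(C#N)cc1)C(=O)Nc1cccc(S(F)(F)(F)(F)F)c1`, keeps the shared core and changes only the aromatic ring at the ether end: 4-cyanophenyl in place of 3-(trifluoromethyl)phenyl on an oxygen on a saturated carbon. In words, this places 4-cyanophenyl in place of 3-(trifluoromethyl)phenyl on an oxygen on a saturated carbon.

Going by the values given here, only one measured step touches this ring with a change of group, a 1.1-fold higher number from compound 2 to compound 3 (0.02 log units; within the scatter), and it stays within the scatter. Among the compounds with values here, no measured step covers a nitrile, so that step is only a weak guide. The one hint of a larger difference is the lower number of compound 1 at 10200 nM, whose ring pattern compound 4 shares. A modest move toward a lower number is therefore expected, though it may not clear the scatter. The estimated step is a 1.8-fold lower number from compound 3 to compound 4 (0.26 log units; within the scatter). For compound 4 the expected value is 16000 nM, with an estimated range from 7000 nM to 35000 nM.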

Compound 4, half-maximal inhibitory concentration: 32500 nM
Compound 4: middle estimate off by 2.0-fold (0.31 log units), on the low side; the measured number falls inside the stated range.
By their numbers in this assay, from the lowest: compound 1; then compounds 2, 3 and 4 (each within the scatter of the next).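

In this assay, the exchange of 3-(trifluoromethyl)phenyl for 4-cyanophenyl on an oxygen on a saturated carbon gives a 1.1-fold higher number from compound 3 to compound 4 (0.05 log units; within the scatter), so even this change of both the group and the ring pattern leaves the number where it was. Going by these compounds alone, the comparison with compound 1 shows something the earlier compounds did not: with the ring pattern held constant, the group on the aromatic carbon alone separates two compounds, as a nitrile in place of the group of five fluorines on sulfur gives a 3.2-fold higher number from compound 1 to compound 4 (0.50 log units; beyond the scatter). The ring pattern shared with compound 1 is thus not enough on its own to bring the number down, although nothing shown explains the difference between these two compounds. On these data alone, what remains open is how a chlorine atom, an amine or a carboxylic acid on that same aromatic carbon would stand against compound 1 at 10200 nM. Also open, as far as these compounds go, is whether that gap would persist if the pentafluorosulfanyl group on the other aromatic ring of the shared core gave way to a trifluoromethyl group.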